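Carboxyphenyl linker variation in a positive allosteric modulator series

This account rests on a few compounds, and the source may have more. Where it says the series, first, only, none or still open, it means among the compounds named here.

Measured in an assay on HEK293 cells for positive allosteric modulation of metabotropic glutamate receptor 2 (Rattus norvegicus), read by thallium flux, with a stated time of 2.5 min; on this read-out higher numbers stand for an effect only at larger amounts of compound and lower numbers for an effect already at smaller amounts:
- compound 1 `Cc1c(OCCCCOCOc2ccc(C(=O)O)cc2)ccc(C(=O)CC2CCCC2)c1O` gives 228 nM
- compound 2 `Cc1c(OCCCCOc2cccc(C(=O)O)c2)ccc(C(=O)CC(C)C)c1C` gives "not active" (no number reported)
- compound 3 `Cc1cc(OCCCCOc2ccc(C(=O)CC(C)C)c(O)c2C)ccc1C(=O)O` gives 173 nM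

Compound 1 has the highest of the two numbers in this assay; compound 3 lies nearest, and the gap between the two is within the scatter, so no order between compound 1 and compound 3 can be read from these values. Compound 2 gives no number in this assay at all.

Compound 4 `Cc1cc(C(=O)O)ccc1OCCCCOc1ccc(C(=O)CC2CCCC2)c(O)c1C` is the next entry. Relative to compound 1 the change is 4-carboxy-2-methylphenyl in place of (4-carboxyphenoxy)methyl on an oxygen on a saturated carbon. Among the measured compounds shown here, no step between measured compounds bears on this change, so the expectation rests on the two numbers alone, which lie close together. The step of a 1.3-fold lower number from compound 1 to compound 4 (0.13 log units; within the scatter) in this assay is expected to be small and not beyond the scatter. Compound 4 is therefore estimated at 170 nM in this assay, with a range from 60 nM to 500 nM.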

Compound 4, half-maximal effective concentration: 608 nM
Beside the measured number, compound 4's estimate is 3.6-fold (0.55 log units) below it; measured number above the stated range.
By their numbers in this assay, from the lowest: compounds 3 and 1 (each within the scatter of the next); then compound 4.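

In this assay, 4-carboxy-2-methylphenyl in place of (4-carboxyphenoxy)methyl on an oxygen on a saturated carbon gives a 2.7-fold higher number from compound 1 to compound 4 (0.43 log units; beyond the scatter), a modest step and the first in the series that can be read. It shows that the group at this place is not freely interchangeable, even though both groups hold one six-membered aromatic ring of carbon only, one double bond outside aromatic rings and one hydrogen-bond donor. Nothing measured here offers an explanation for the step.

As far as these compounds go, because the whole group changes at once, it stays open whether the added methyl or the lost (4-carboxyphenoxy)methyl linkage goes with the higher number. Also open, from the compounds shown here alone, is how a tetrazole in place of the carboxylic acid would behave at this place.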